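A few compounds are considered here, and "the series" means these few. Any claim that something is new, unique, unknown or untested is made for them only; others in the source may bear on it.

Compound 1 `c1ccc(-c2cc3n(n2)CCCC3)cc1`: 1900 nM
Compound 2 `FC(F)(F)c1cccc(-c2cc3n(n2)CCCC3)c1`: 3990 nM

For the measured compounds named here, in a functional assay on HEK293 cells for negative allosteric modulation of metabotropic glutamate receptor 5 (Rattus norvegicus), read by FLIPR and calcium flux, with a stated time of 170 s (a lower number here means a stronger inhibitor, a higher number a weaker inhibitor), compound 2 gives 3990 nM, the higher of the two numbers measured so far. Going by the values given here, the only measured step, a 2.1-fold higher number from compound 1 to compound 2 (0.32 log units; beyond the scatter), shows that adding trifluoromethyl weakened inhibition modestly. Compound 3 `Fc1cccc(-c2cc3n(n2)CCCC3)c1` differs from compound 2 by fluoro in place of trifluoromethyl on an aromatic carbon. Among the compounds with values here, no measured pair shows exactly this change, so the expectation rests on that single step alone: compound 3 is expected to land between the two measured values, a step of a 1.6-fold lower number from compound 2 to compound 3 (0.20 log units; within the scatter). Compound 3 is therefore estimated at 2500 nM, with a range from 1000 nM to 6000 nM.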

Compound 3, half-maximal inhibitory concentration: 1570 nM
For compound 3 the middle estimate is 1.6-fold (0.20 log units) above the measured one, within the range that was stated.
By their numbers in this assay, from the lowest: compounds 3 and 1 (each within the scatter of the next); then compound 2.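

Putting fluoro in place of trifluoromethyl on this aromatic carbon gives a 2.5-fold lower number from compound 2 to compound 3 (0.41 log units; beyond the scatter) and restores the inhibition that trifluoromethyl had cost. Fluoro in place of hydrogen gives a 1.2-fold lower number from compound 1 to compound 3 (0.08 log units; within the scatter) and so cannot be told apart from hydrogen here, which leaves trifluoromethyl as the only one of these three groups that stands out, as the weaker inhibitor. Nothing measured here explains why these groups differ. Going by these compounds, whether a nitrile, a methoxy group or an amine on this carbon would read like fluoro or like trifluoromethyl stays open. So does whether any group here could give stronger inhibition than hydrogen does.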